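The source may hold more compounds than are shown below. What is called first, only, known or untested is meant among the compounds shown, and "the series" means these compounds.

Compound 1 `Nc1nc2cc(-c3nn(CCC(=O)NO)c4ncnc(N)c34)ccc2o1`: > 100000 nM (a limit of the assay)
Compound 2 `Nc1nc2cc(-c3nn(CCCCCC(=O)NO)c4ncnc(N)c34)ccc2o1`: 21500 nM

Within the data shown here, in a functional assay on HCT-116 cells (Homo sapiens) for inhibition, read by MTT assay, with a stated time of 72 h (a higher number here means a weaker inhibitor, a lower number a stronger inhibitor), compound 2 gives 21500 nM, the only actual number so far. Compound 1 reads > 100000 nM, which is a limit and not a number.

Compound 3 `CNC(=O)CCCCCCCn1nc(-c2ccc3oc(N)nc3c2)c2c(N)ncnc21` differs from compound 2 as follows: 2-(methylcarbamoyl)ethyl in place of hydroxycarbamoyl on a saturated chain carbon, five bonds along the chain from an aromatic nitrogen. It carries 2-(methylcarbamoyl)ethyl in place of hydroxycarbamoyl on a saturated chain carbon, five bonds along the chain from an aromatic nitrogen. Among the measured compounds shown here, one measured step bears on this, an at least 4.6-fold lower number from compound 1 to compound 2 (0.66 log units; beyond the scatter), and hydroxycarbamoyl remains present on both sides of it. Removing that group has not been measured, so no clear shift is expected in this assay. The estimated step is a 1.4-fold lower number from compound 2 to compound 3 (0.16 log units; within the scatter), within the scatter. For compound 3 the expected value is 15000 nM, with an estimated range of 2500 nM to 90000 nM.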

Compound 3, half-maximal inhibitory concentration: 3150 nM
Beside the measured number, compound 3's estimate is 4.8-fold (0.68 log units) above it, within the range that was stated.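

In this assay, the hydroxycarbamoyl group proves dispensable for this read-out: putting 2-(methylcarbamoyl)ethyl in its place, on a saturated chain carbon five bonds along the chain from an aromatic nitrogen, gives a 6.8-fold lower number from compound 2 to compound 3 (0.83 log units; beyond the scatter). The wider change to 5-(methylcarbamoyl)pentyl gives an at least 31-fold lower number from compound 1 to compound 3 (1.50 log units; beyond the scatter). That step starts from a limit of the assay, not a number: the limit of > 100000 nM in this assay, at which 1 of the 3 values shown sits.

On these data alone, compound 3 extends the chain and replaces the end group at once, so the share of each stays open. A hydroxycarbamoyl group on the longer chain, or a carboxylic acid at its end, would help separate them.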